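The source may hold more compounds than are shown below. What is called first, only, known or untested is meant among the compounds shown, and "the series" means these compounds.

Compound 1 `O=C(NC1CCCCC1)Oc1ccc(Cl)cc1C(=O)Nc1ccc(Br)cc1`: 9400 nM
Compound 2 `O=C(Nc1ccccc1)Oc1ccc(Cl)cc1C(=O)Nc1ccc(C(F)(F)F)cc1`: 2450 nM

In an ADME assay on HepG2 cells (Homo sapiens), read by MTT assay, with a stated time of 72 h, in the presence of a further agent that is not named here (on this read-out higher numbers stand for weaker inhibition and lower numbers for stronger inhibition), compound 2 gives 2450 nM, the lower of the two numbers, and its gap to compound 1 lies beyond the usual scatter. Compound 3 `O=C(NC1CCCCC1)Oc1ccc(Cl)cc1C(=O)Nc1ccc(C(F)(F)F)cc1` has cyclohexyl in place of phenyl on an amide-type nitrogen of compound 2: cyclohexyl in place of phenyl on an amide-type nitrogen. Going by the values given here, no measured pair shows this change alone. Compound 1 also carries cyclohexyl there, differs elsewhere too, and gives 9400 nM, so a moderate rise towards weaker inhibition is expected. The expected step is a 2.0-fold higher number from compound 2 to compound 3 (0.31 log units; beyond the scatter). Compound 3 is estimated at 5000 nM, within an expected range of 2000 nM to 12000 nM.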

Compound 3, half-maximal inhibitory concentration: 750 nM
Compound 3: middle estimate off by 6.7-fold (0.82 log units), on the high side; the whole stated range lies above it.
By their numbers in this assay, from the lowest: compound 3; then compound 2; then compound 1.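

In this assay, a direct comparison now shows cyclohexyl in place of phenyl on the amide-type nitrogen going with stronger inhibition, with a 3.3-fold lower number from compound 2 to compound 3 (0.51 log units; beyond the scatter) as the step. Compound 1 and compound 3 differ only in the aromatic substituent, and trifluoromethyl in place of bromo gives a 13-fold lower number from compound 1 to compound 3 (1.10 log units; beyond the scatter) as its step, again towards stronger inhibition. Nothing available here explains either step.

From the compounds shown here alone, whether a smaller ring such as cyclopentyl or an open hexyl chain on that nitrogen would behave like cyclohexyl remains open. So does whether an amine or a carboxylic acid in place of trifluoromethyl would keep this inhibition.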